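Methyl in Place of Methoxy: What to Expect for Compound 4

This account rests on a few compounds, and the source may have more. Where it says the series, first, only, none or still open, it means among the compounds named here.

Measured so far:
Compound 1, `C=CC(=O)N1CC[C@H](N2C(=O)N(C3CCCC3)Cc3cnc(Nc4ccc(N5CCN(C)CC5)cc4OC)nc32)C1`: 250 ug/mL
Compound 2, `C=CC(=O)N1CC[C@H](N2C(=O)N(c3ccccc3)Cc3cnc(Nc4ccc(N5CCN(C)CC5)c(OC)c4)nc32)C1`: 256 ug/mL
Compound 3, `C=CC(=O)NCCN1C(=O)N(Cc2ccccc2)Cc2cnc(Nc3ccc(N4CCN(C)CC4)cc3OC)nc21`: 96.7 ug/mL

These three compounds were examined in a physicochemical assay for solubility, read by HPLC, in phosphate buffer, measured as thermodynamic solubility, with a stated time of 24 h, at pH 6.8; on this read-out higher numbers stand for higher solubility and lower numbers for lower solubility. Compound 2 gives the highest of the three numbers. Its nearest neighbour is compound 1, whose value lies within the usual scatter of compound 2, so no order between these two can be claimed. The furthest is compound 3, whose lower value lies beyond the scatter, so compound 3 stands clearly lower than compound 2 in this assay.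

The next compound, compound 4, `C=CC(=O)N1CC[C@H](N2C(=O)N(c3ccccc3)Cc3cnc(Nc4ccc(N5CCN(C)CC5)c(C)c4)nc32)C1`, is a close relative of compound 2. The change is methyl in place of methoxy on an aromatic carbon, on the aromatic carbon ortho to the 4-methylpiperazin-1-yl group and meta to a large group. Among the compounds with values here, no measured pair in this set shows this same change, so there is no directly comparable step to lean on.

Given that, and since this change removes one hydrogen-bond acceptor and one heavy atom, compound 4 is expected to sit a little lower than compound 2, with a step of a 1.6-fold lower number from compound 2 to compound 4 (0.20 log units; within the scatter) that may well fall within the scatter. The estimated value for compound 4 in this assay is 160 ug/mL, with a range from 60 ug/mL to 350 ug/mL.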

Compound 4, solubility: 1270 ug/mL
Beside the measured number, compound 4's estimate is 7.9-fold (0.90 log units) below it; the measured number lies above the stated range.
By their numbers in this assay, from the lowest: compound 3; then compounds 1 and 2 (each within the scatter of the next); then compound 4.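

In this assay, putting methyl in place of methoxy on the aromatic carbon ortho to a 4-methylpiperazin-1-yl group gives a 5.0-fold higher number from compound 2 to compound 4 (0.70 log units; beyond the scatter) and so lifts the number past what repeated measurements would scatter by. Within the data shown here, this is the first pair in the set that differs in one place only, and it shows that this single position can move the read-out clearly, something compounds 1, 2 and 3, which differ in several places at once, could not show. Methoxy brings 2 heavy atoms and 1 hydrogen-bond acceptor where methyl brings 1 heavy atom and no acceptor, but nothing measured here says why the number moves.

Among these compounds, with only this one pair, it stays open whether the same swap would give a step of similar size in the settings of compound 1 or compound 3, which differ from compound 2 elsewhere in the molecule. On these data alone, it is also open how an ethyl group, a chlorine atom, a plain hydrogen or an amine at this carbon would compare with methyl and methoxy.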